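The source may hold more compounds than are shown below. What is called first, only, known or untested is meant among the compounds shown, and "the series" means these compounds.

Two compounds carrying the same amide linked to a piperidine bearing a difluorobenzyl group have been examined for growth inhibition. Compound 1 `O=C(Nc1ccc2scnc2c1)C1CCCN(Cc2ccc(F)c(F)c2)C1` was tested in a functional assay on A-375 cells (Homo sapiens) for antiproliferative activity (a lower number here means a stronger inhibitor, a higher number a weaker inhibitor), and gave only a limit of the assay, > 20000 nM (the limit of > 20000 nM in this assay, at which 1 of the 2 values shown sits). Within the data shown here, compound 2 `O=C(Nc1ccc(-c2ccccc2)cc1)C1CCCN(Cc2ccc(F)c(F)c2)C1`, in which a biphenyl amine replaces the benzothiazole amine, gives 2580 nM in this assay; this is the only actual number among the two results. The next compound, compound 3 `O=C(Nc1ccc(-c2cccs2)cc1)C1CCCN(Cc2ccc(F)c(F)c2)C1`, differs from compound 2 in a single place: thiophen-2-yl in place of phenyl on an aromatic carbon. Among the measured compounds shown here, no measured pair of compounds shows what such a swap does to activity here, so the expectation rests on the change itself rather than on an observed step. Exchanging a six-membered aromatic ring of carbon only for a five-membered aromatic ring with one hetero atom of similar size is expected to leave this assay close to where compound 2 stands, with no shift beyond the scatter in either direction. Compound 3 is therefore estimated at 2500 nM, with a plausible range from 1000 nM to 6500 nM. The expected step is a 1.0-fold lower number from compound 2 to compound 3 (0.01 log units; within the scatter).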

Compound 3, half-maximal inhibitory concentration: 390 nM
Estimate against measurement, compound 3: 6.4-fold (0.81 log units) above, and the stated range ends above it.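

In this assay, among these compounds, thiophen-2-yl in place of phenyl gives a 6.6-fold lower number from compound 2 to compound 3 (0.82 log units; beyond the scatter), the first step that can be read as a measured change at a single place. The aromatic carbon para to a large group therefore does not tolerate this exchange as a neutral one: a five-membered aromatic ring with one hetero atom and a six-membered aromatic ring of carbon only, though they sit at the same place on an otherwise unchanged structure, give clearly different results. Nothing measured here accounts for the difference between the two rings.

The compounds shown leave open whether the gain belongs to thiophen-2-yl alone or would also appear with other groups at this place, such as an amine, a methoxy group or a carboxylic acid. They also leave open whether the step would keep its size if another group, for example a plain benzyl or a longer chain, stood in place of the difluorobenzyl group on the piperidine.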